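A few compounds are considered here, and "the series" means these few. Any claim that something is new, unique, unknown or untested is made for them only; others in the source may bear on it.

Working notes on the series. Of the compounds shown here, two have numbers so far. Compound 1 `CN1CCN(c2ccc(Nc3ncc4nc(Nc5ccc(F)cc5)n([C@H]5CCCN(S(=O)(=O)C6CC6)C5)c4n3)cc2)CC1` gives 8.6 nM in a functional assay on HCC827 cells (Homo sapiens) for antiproliferative activity, read by MTT assay, with a stated time of 72 h (a lower number here means a stronger inhibitor, a higher number a weaker inhibitor), and compound 2 `CN1CCN(c2ccc(Nc3ncc4nc(Nc5ccccc5)n([C@H]5CCN(S(=O)(=O)C6CC6)C5)c4n3)cc2)CC1` gives 1.6 nM in this assay. Compound 1 thus stands at the higher of the two numbers, with compound 2 a lower number beyond the scatter; the two differ in more than one place, so their values are taken only as they stand, with no single change to read from them.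

Compound 3 `CN1CCN(c2ccc(Nc3ncc4nc(Nc5ccc(F)cc5)n([C@@H]5CCCN(C(=O)CO)C5)c4n3)cc2)CC1` is the next compound of interest and is not yet measured. It differs from compound 1 by 1-((hydroxymethyl)carbonyl)piperidin-3-yl in place of 1-(cyclopropylsulfonyl)piperidin-3-yl on an aromatic nitrogen. Among the compounds with values here, no step of this kind has been measured, so the expectation rests on compound 1 alone. The estimate is a modest shift, if any, toward a higher number, with the step of a 1.4-fold higher number from compound 1 to compound 3 (0.14 log units; within the scatter) expected to sit close to the scatter. For compound 3 the expected value in this assay is 12 nM, with a range from 4 nM to 35 nM.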

Compound 3, half-maximal inhibitory concentration: 66 nM
The estimate for compound 3 lay 5.5-fold (0.74 log units) below the measured number; the whole stated range lies below it.
By their numbers in this assay, from the lowest: compound 2; then compound 1; then compound 3.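

The substituent on this aromatic nitrogen is not neutral to the activity: in this assay the change to 1-((hydroxymethyl)carbonyl)piperidin-3-yl gives a 7.7-fold higher number from compound 1 to compound 3 (0.89 log units; beyond the scatter) on the same core with the same (4-fluorophenyl)amino group. Within the data shown here, this is the first single-place step, and it shows that 1-(cyclopropylsulfonyl)piperidin-3-yl is the better of these two groups here. Nothing measured bears on the origin of this step.

The step removes the sulfonyl and the three-membered ring and adds a carbonyl and one hydrogen-bond donor all at once, and the compounds shown do not separate these parts. Open, as far as these compounds go, is how a 1-acetylpiperidin-3-yl, lacking the hydroxyl, or a 1-(methylsulfonyl)piperidin-3-yl, lacking the cyclopropyl, would stand in this assay against these two compounds.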